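Urea aryl swap: methoxyphenyl to chlorophenyl on the trifluoromethyl core

This account rests on a few compounds, and the source may have more. Where it says the series, first, only, none or still open, it means among the compounds named here.

Compound 3 `CCNc1cc(-c2ccc(NC(=O)Nc3ccc(OC)cc3)cc2C(F)(F)F)ccn1` stands second highest of the three measured in an assay on isolated protein for inhibition of serine/threonine-protein kinase PLK1 (Homo sapiens), read by radiometric assay and 33P incorporation, with a stated time of 40 min, tested at 20 uM, in the presence of a further agent that is not named here (on this read-out lower numbers stand for less inhibition and higher numbers for more inhibition at the one concentration tested (going by the name of the read-out)), giving 62.1%; compound 1 `CCNc1cc(-c2ccc(NC(=O)Nc3cccc(Cl)c3)cc2C)ccn1` gives 82.7% and compound 2 `CCNc1cc(-c2ccc(NC(=O)Nc3ccc(OC)cc3)cc2C)ccn1` gives 45.8%. Compound 4 `CCNc1cc(-c2ccc(NC(=O)Nc3ccccc3Cl)cc2C(F)(F)F)ccn1` differs from compound 3 by 2-chlorophenyl in place of 4-methoxyphenyl on an amide-type nitrogen. Among the compounds with values here, the only step that bears on this exchange is a number 36.9 percentage points lower from compound 1 to compound 2 (beyond the scatter), where a chlorophenyl was replaced by the methoxyphenyl; the step here runs the other way, though the chlorine sits at a different position of the ring, so its size is not fixed by that one pair. A rise beyond the scatter is expected because a number 36.9 percentage points lower from compound 1 to compound 2 (beyond the scatter) was large. Compound 4 is estimated at 82% (range 60% to 97%), an expected step of a number 19.9 percentage points higher from compound 3 to compound 4 (beyond the scatter).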

Compound 4, a percentage reported as inhibition, at one concentration (the size of the read-out at that concentration, not a potency): 71.6%
For compound 4 the middle estimate is 10.4 percentage points above the measured one; low and high end bracket the measured number.
By their numbers in this assay, from the lowest: compound 2; then compounds 3 and 4 (each within the scatter of the next); then compound 1.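

On this core, in this assay, the exchange on the amide-type nitrogen gives a number 9.5 percentage points higher from compound 3 to compound 4 (within the scatter), so 2-chlorophenyl and 4-methoxyphenyl are not separated here. The large gap in a number 36.9 percentage points lower from compound 1 to compound 2 (beyond the scatter) does not recur in this pair, although the two pairs also differ in chlorine position and in the aromatic substituent of the core, so the data cannot assign the contrast to either difference. No evidence bears on the reason for this result.

Still open, as far as these compounds go, is how 3-chlorophenyl would read on the trifluoromethyl core, which would separate chlorine position from the core change. Also open, from the compounds shown here alone, is how a 4-chlorophenyl, or a phenyl ring carrying a carboxylic acid or a dimethylamino group, would read at this position.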